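Swapping the bromobenzyl group of compound 2 for a decyl chain

The compounds below may be only part of what the source reports. "The series", "measured", "known", "first", "only" and "open" are said of these compounds alone.

Three compounds have been measured in a functional assay on SK-N-SH cells (Homo sapiens) for inhibition, read by MTT assay; a higher number here means a weaker inhibitor, a lower number a stronger inhibitor:

compound 1 `O=C(CN1CCN(c2ccccc2F)CC1)Nc1ccc(C(=O)/C=C/c2cn(Cc3ccc(Br)cc3)nn2)cc1`: 12800 nM
compound 2 `COc1ccccc1N1CCN(CC(=O)Nc2ccc(C(=O)/C=C/c3cn(Cc4ccc(Br)cc4)nn3)cc2)CC1`: 28000 nM
compound 3 `O=C(CN1CCN(c2ccccc2)CC1)Nc1ccc(C(=O)/C=C/c2cn(Cc3ccc(Br)cc3)nn2)cc1`: 72400 nM

Compound 2 sits in the middle of the three: a 2.2-fold higher number from compound 1 to compound 2 (0.34 log units; beyond the scatter), and a 2.6-fold higher number from compound 2 to compound 3 (0.41 log units; beyond the scatter). The unmeasured compound 4 `CCCCCCCCCCn1cc(/C=C/C(=O)c2ccc(NC(=O)CN3CCN(c4ccccc4OC)CC3)cc2)nn1` changes a different part of the molecule: nonyl in place of 4-bromophenyl on a saturated chain carbon bound to an aromatic nitrogen. None of the three measured steps touches this position; each of them only alters the substituent on the aromatic ring attached to the piperazine, so the data give no direct guide to the new change. The step from compound 2 to compound 4 in this assay is therefore expected to be a 1.1-fold lower number from compound 2 to compound 4 (0.05 log units; within the scatter), with wide uncertainty. Compound 4 is estimated at 25000 nM, most likely between 6000 nM and 100000 nM.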

Compound 4, half-maximal inhibitory concentration: 87600 nM
Compound 4: the middle estimate sits 3.5-fold (0.54 log units) below what was measured; the measured number falls inside the stated range.
By their numbers in this assay, from the lowest: compound 1; then compound 2; then compounds 3 and 4 (each within the scatter of the next).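

The earlier steps shown here changed only a substituent on an aromatic carbon; compound 4 shows that the place on a saturated chain carbon bound to an aromatic nitrogen also affects the number in this assay. Nonyl in place of 4-bromophenyl gives a 3.1-fold higher number from compound 2 to compound 4 (0.50 log units; beyond the scatter) and makes compound 4 the weaker inhibitor of the pair. Nothing available accounts for this shift.

On these data alone, whether a shorter chain, a plain benzyl or a chain ending in an amine would give a lower number remains open. So does whether the fluoro group of compound 1 would keep its lower number alongside decyl.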